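A few compounds are considered here, and "the series" means these few. Any claim that something is new, unique, unknown or untested is made for them only; others in the source may bear on it.

Measured so far:
- compound 1 `Cc1cc(C)c(NC(=O)N(Cc2cc(-c3ccccc3)on2)C2CCCCCC2)c(C)c1`: > 1 mg/kg (a limit)
- compound 2 `Cc1cc(C)c(NC(=O)N(Cc2ccc(-c3n[nH]c(C)n3)cc2)C2CCCCCC2)c(C)c1`: > 1 mg/kg (a limit)
- compound 3 `CSc1cc(C)nc(SC)c1NC(=O)N(Cc1ccccc1)Cc1cccc(-c2ccn(C)n2)c1`: < 1 mg/kg (a limit)

In a functional assay on a cell-free system (plasma) with sterol O-acyltransferase, Soat (Rattus norvegicus) as the target (a higher number here means that more compound is needed for the effect, a lower number that less compound is needed), compound 1 reaches only a limit, > 1 mg/kg. Compound 2 likewise gives only a limit, > 1 mg/kg. Compound 3 gives a limit as well, < 1 mg/kg. Compound 2 thus stands at the limit of > 1 mg/kg in this assay, at which 2 of the 3 values shown sit, shared with compound 1, whereas compound 3 sits at the limit of < 1 mg/kg in this assay, at which 1 of the 3 values shown sits. For the measured compounds named here, no number exists for any of the three, and none of them differs from another in a single place, so no measured step is available.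

Compound 4 `Cc1cc(C)c(NC(=O)N(Cc2ccc(-n3ccnc3)cc2)C2CCCCCC2)c(C)c1` differs from compound 2 by 1H-imidazol-1-yl in place of 5-methyl-1H-1,2,4-triazol-3-yl on an aromatic carbon. Going by the values given here, no measured step bears on this change. The step that the limit leaves unreadable from compound 2 to compound 4 is expected to stay within the scatter, with no clear direction, since compound 1 of the same core also sits at the limit of > 1 mg/kg in this assay, at which 2 of the 3 values shown sit. Compound 4 is therefore estimated at 2 mg/kg in this assay, within 0.7 mg/kg to 6 mg/kg, and most likely again reported only as a limit.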

Compound 4, dose for half-maximal effect: > 1 mg/kg
Compound 4: only a limit was reported; the forecaster's own chance of this, stated with the estimate: 70%; the middle value does not contradict the limit.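

In this assay compound 4 gives only a limit, > 1 mg/kg. For the compounds shown here, compound 2 also gives a limit, > 1 mg/kg, and no step between compound 2 and compound 4 can be read. The compounds shown leave open whether 1H-imidazol-1-yl and 5-methyl-1H-1,2,4-triazol-3-yl differ at all on the shared core in this assay.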